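Methoxy Added to a Thiosemicarbazone Core: Expected Effect

A few compounds are considered here, and "the series" means these few. Any claim that something is new, unique, unknown or untested is made for them only; others in the source may bear on it.

Measured so far, in a functional assay on 786-0 cells (Homo sapiens) for inhibition, read by sulforhodamine B assay, with a stated time of 48 h; a lower number here means a stronger inhibitor of growth, a higher number a weaker inhibitor of growth:
- compound 1 `CC1=CC[C@H](C(C)(C)NC(=S)N/N=C/c2ccc(O)cc2)CC1`: a limit of > 100000 nM, not a number
- compound 2 `COc1cc(/C=N/NC(=S)NC(C)(C)[C@H]2CC=C(C)CC2)ccc1O`: 12900 nM
- compound 3 `CC1=CC[C@H](C(C)(C)NC(=S)N/N=C(\C)c2ccccc2)CC1`: a limit of > 100000 nM, not a number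

Going by the values given here, the one measured step is methoxy in place of hydrogen on an aromatic carbon, which gave an at least 7.7-fold lower number from compound 1 to compound 2 (0.88 log units; beyond the scatter). Its size is not settled because of the limit of > 100000 nM in this assay, at which 2 of the 3 values shown sit.

Compound 4 `COc1ccc(/C(C)=N/NC(=S)NC(C)(C)[C@H]2CC=C(C)CC2)cc1` is not yet measured. It is made from compound 3 by the same kind of change, (methoxy in place of hydrogen on an aromatic carbon), but around a different place. How the core of compound 1 differs from that of compound 3 is not broken down here.

For compound 4 the step is expected to be an at least 2.5-fold lower number from compound 3 to compound 4 (0.39 log units; beyond the scatter), resting on the step from compound 1 to compound 2, though a limit gives it a wide margin. In this assay compound 4 is therefore estimated at 40000 nM, between 8000 nM and 100000 nM.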

Compound 4, concentration for 50% growth inhibition: > 100000 nM
Compound 4: no number, only a limit; the forecaster's own chance of this, stated with the estimate: 50%; middle value at least 2.5-fold (0.39 log units) from the limit.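

In this assay, compound 3 and compound 4 each give only a limit, not a number, so the step between them cannot be read: the limit of > 100000 nM in this assay, at which 3 of the 4 values shown sit.

The compounds shown leave open whether methoxy changes the number at all on the core of compound 3.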